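This account rests on a few compounds, and the source may have more. Where it says the series, first, only, none or still open, it means among the compounds named here.

Three compounds have been measured in an ADME assay on BJ cells (Homo sapiens), read by MTT assay, with a stated time of 72 h; on this read-out lower numbers stand for stronger inhibition and higher numbers for weaker inhibition:
- compound 1 `CN(C)c1ncnc2c1c(-c1ccoc1)cn2[C@@H]1O[C@H](CO)[C@@H](O)[C@H]1O`: 99200 nM
- compound 2 `CN(C)c1ncnc2c1c(-c1cc3ccccc3o1)cn2[C@@H]1O[C@H](CO)[C@@H](O)[C@H]1O`: > 100000 nM (a limit of the assay, not a number)
- compound 3 `Cc1ncnc2c1c(-c1ccoc1)cn2[C@@H]1O[C@H](CO)[C@@H](O)[C@H]1O`: 89200 nM

For the measured compounds named here, compound 3, at 89200 nM, cannot be told apart from compound 1, the only other compound with a number. The gap between them is a 1.1-fold lower number from compound 1 to compound 3 (0.05 log units; within the scatter). Compound 2 has only a limit, > 100000 nM.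

The next compound is compound 4 `Cc1ncnc2c1c(-c1cc3ccccc3o1)cn2[C@@H]1O[C@H](CO)[C@@H](O)[C@H]1O`, which differs from compound 3 by one change: 1-benzofuran-2-yl in place of furan-3-yl on an aromatic carbon. In words, 1-benzofuran-2-yl stands in place of furan-3-yl on an aromatic carbon. The same exchange has been measured once, on the dimethylamino member of the series, and it gave a number no lower from compound 1 to compound 2 (the limit leaves the size open). That step fixes a direction but no size. The exchange of dimethylamino for methyl, seen in a 1.1-fold lower number from compound 1 to compound 3 (0.05 log units; within the scatter), gives no reason to expect a different direction on the methyl member.

A small move towards a higher number is therefore expected, possibly not beyond the scatter. The expected step is a 1.2-fold higher number from compound 3 to compound 4 (0.09 log units; within the scatter). The assay may well report only a limit here, as it did at the limit of > 100000 nM in this assay, at which 1 of the 3 values shown sits. The estimated value for compound 4 is 110000 nM, with an expected range from 60000 nM to 200000 nM.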

Compound 4, half-maximal inhibitory concentration: 93900 nM
For compound 4 the middle estimate is 1.2-fold (0.07 log units) above the measured one; low and high end bracket the measured number.
By their numbers in this assay, from the lowest: compounds 3, 4 and 1 (each within the scatter of the next). At a limit, above all of these: compound 2.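

In this assay, the larger 1-benzofuran-2-yl group brings a six-membered aromatic ring of carbon only to this aromatic carbon, and on the methyl member the exchange for furan-3-yl gives a 1.1-fold higher number from compound 3 to compound 4 (0.02 log units; within the scatter). This is the first readable size for the exchange at this position, and it lies within the scatter, while on the dimethylamino member the size stays unread: the same change on two cores in this assay, a number no lower (the limit leaves the size open) from compound 1 to compound 2 and a 1.1-fold higher number (0.02 log units; within the scatter) from compound 3 to compound 4; the limit leaves it open whether they differ The exchange of dimethylamino for methyl, now seen with 1-benzofuran-2-yl in place, gives an at least 1.0-fold lower number from compound 2 to compound 4 (0.02 log units; that floor lies within the scatter), which is only a floor, so it does not show whether this change behaves alike with both groups: the same change on two cores in this assay, a 1.1-fold lower number (0.05 log units; within the scatter) from compound 1 to compound 3 and an at least 1.0-fold lower number (0.02 log units; that floor lies within the scatter) from compound 2 to compound 4; the limit leaves it open whether they differ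

The compounds shown leave open how this assay would read with a primary amine or a carboxylic acid in place of these aromatic groups on the same carbon, since both groups tried here are aromatic rings with one oxygen. They also leave open how far the numbers could rise on this series, as one value already stands at a limit: the limit of > 100000 nM in this assay, at which 1 of the 4 values shown sits.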